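Halogen variation on the benzyl group: cytotoxicity notes

This account rests on a few compounds, and the source may have more. Where it says the series, first, only, none or still open, it means among the compounds named here.

Of the compounds shown here, three have been measured in an ADME assay on HOS cells (Homo sapiens) for cytotoxicity; on this read-out higher numbers stand for weaker inhibition and lower numbers for stronger inhibition. Compound 1 `O=C1c2c(ccc(O)c2O)CN1Cc1cccc(F)c1` gives 8600 nM. In this assay compound 2 `O=C1c2c(ccc(O)c2O)CN1Cc1cccc(Cl)c1` gives 9020 nM. In this assay compound 3 `O=C1c2c(ccc(O)c2O)CN1Cc1cc(F)ccc1F` gives 13400 nM. All three numbers lie within the usual scatter of one another, so no order among them can be claimed.

The cores of compound 1 and compound 2 differ by chloro in place of fluoro on an aromatic carbon. The matching step is a 1.0-fold higher number from compound 1 to compound 2 (0.02 log units; within the scatter). From compound 1 to compound 3 the change is fluoro in place of hydrogen on an aromatic carbon, and the step is a 1.6-fold higher number from compound 1 to compound 3 (0.19 log units; within the scatter).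

Compound 4 `O=C1c2c(ccc(O)c2O)CN1Cc1cccc(Cl)c1F` has not yet been measured. It differs from compound 2 by fluoro in place of hydrogen on an aromatic carbon. Within the data shown here, this is the same kind of change as the one from compound 1 to compound 3, made twice among the compounds here, but the surroundings are not the same: in compound 4 the entering fluoro is ortho to a chloro group, whereas in compound 3 it is para to a fluoro group. Among the measured compounds shown here, the one measured instance of this kind of change stayed within the scatter.

Compound 4 is expected to show a step of a 1.3-fold higher number from compound 2 to compound 4 (0.12 log units; within the scatter) in this assay. This expectation rests on the step from compound 1 to compound 3, which gave a 1.6-fold higher number from compound 1 to compound 3 (0.19 log units; within the scatter). In this assay compound 4 is expected to give 12000 nM, with a range from 6000 nM to 24000 nM.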

Compound 4, half-maximal inhibitory concentration: 9430 nM
Beside the measured number, compound 4's estimate is 1.3-fold (0.10 log units) above it, and the stated range covers the measured number.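

Working note on carrying the change: in this assay, fluoro in place of hydrogen on an aromatic carbon gives a 1.0-fold higher number from compound 2 to compound 4 (0.02 log units; within the scatter), and the two instances of this change in the series do not differ: the same change on two cores in this assay, a 1.6-fold higher number (0.19 log units; within the scatter) from compound 1 to compound 3 and a 1.0-fold higher number (0.02 log units; within the scatter) from compound 2 to compound 4, 1.5-fold (0.17 log units) apart, within the scatter of two such steps. On these two cores, the change therefore carries over in the limited sense that neither step leaves the scatter and the gap between them stays inside it, even though the entering fluoro is ortho to a chloro group in compound 4 and has different surroundings in compound 3. This does not show that fluoro in place of hydrogen is without effect throughout the series, since two small steps on closely related cores say nothing about other cores or other surroundings, and they give no ground for ranking compound 1, compound 2, compound 3 and compound 4.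

The compounds shown leave open whether a group other than a halogen on the six-membered aromatic ring, such as an amine, a carboxylic acid or a longer chain, would stay within the scatter as well. They also leave open whether replacing a hydroxyl group on the shared core with a methoxy group would alter the number in this read-out.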